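The source may hold more compounds than are shown below. What is called first, only, known or untested is meant among the compounds shown, and "the series" means these compounds.

Compound 1 `Cc1cccc(NC(=O)NC2CC(C)(C)Oc3ccc(F)cc32)c1` in a functional assay (aorta) with Rattus norvegicus as the target (a lower number here means that less compound is needed, a higher number that more compound is needed for the effect), gives > 30000 nM, which is a limit of the assay and not a number.
Compound 2 `Cc1ccc(NC(=O)NC2CC(C)(C)Oc3ccc(F)cc32)cc1` in this assay gives > 30000 nM, again a limit of the assay.
Compound 3 `CC1(C)CC(NC(=O)Nc2ccccc2Cl)c2cc(F)ccc2O1` in this assay gives > 30000 nM, also a limit of the assay.

Compound 3 thus stands at the limit, and so do the two other measured compounds: the limit of > 30000 nM in this assay, at which 3 of the 3 values shown sit. The steps among them, a step that the two limits leave unreadable from compound 1 to compound 2, a step that the two limits leave unreadable from compound 1 to compound 3 and a step that the two limits leave unreadable from compound 2 to compound 3, are unreadable in size; both ends of each sit at a limit. Compound 4 `CC1(C)CC(NC(=O)Nc2cccc(Cl)c2)c2cc(F)ccc2O1` differs from compound 3 by 3-chlorophenyl in place of 2-chlorophenyl on an amide-type nitrogen. Within the data shown here, no measured step exchanges one chlorophenyl for another; the three unreadable steps show only that a 3-methylphenyl, a 4-methylphenyl and a 2-chlorophenyl on this nitrogen all left the compounds outside the measured range. For compound 4 the step that the limit leaves unreadable from compound 3 to compound 4 is expected to be small and most likely to leave the compound at the limit as well. Compound 4 is estimated at 60000 nM, with a range from 20000 nM to 300000 nM, and the most probable outcome is that only a limit is reported.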

Compound 4, half-maximal effective concentration: > 300000 nM
Compound 4 ended at the assay's limit (the forecaster's own chance of this, stated with the estimate: 85%); middle value at least 5.0-fold (0.69 log units) from the limit.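

Compound 4 gives > 300000 nM in this assay, which is a limit of the assay and not a number, so its steps from compound 1, compound 2 and compound 3 cannot be read. The compounds shown leave open which group on this nitrogen, if any, would give a value inside the measured range.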